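The source may report more compounds than this note shows. Statements on the series, on what has been measured and on what is new or still open speak of the compounds shown alone.

Working notes on the series, side chain on the shared core. Compound 3 `Cn1cncc1C(OCc1ccc(C#N)cc1C#Cc1cccc(O)c1)c1ccc(C#N)cc1` stands in a functional assay on NIH3T3 cells (Mus musculus) (on this read-out lower numbers stand for an effect already at smaller amounts and higher numbers for an effect only at larger amounts of compound), only as a limit, > 0.1 nM. In this assay compound 1 `Cn1cncc1C(OCc1ccc(C#N)cc1C#CCCCCO)c1ccc(C#N)cc1` gives 20.9 nM, and compound 2 `Cn1cncc1C(OCc1ccc(C#N)cc1/C=C/c1ccc([N+](=O)[O-])cc1)c1ccc(C#N)cc1` gives 2.24 nM.

Compound 4 `Cn1cncc1C(OCc1ccc(C#N)cc1C#CCCc1ccccc1)c1ccc(C#N)cc1` carries phenethyl in place of 3-hydroxyphenyl on a triple-bonded carbon. The same difference, cut one bond further out, reads 2-(3-hydroxyphenyl)ethynyl to 4-phenylbut-1-yn-1-yl.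

The steps closest to this change, a step that the limit leaves unreadable from compound 1 to compound 3 and a step that the limit leaves unreadable from compound 2 to compound 3, cannot be sized. Among the measured compounds shown here, the only readable step is a 9.3-fold lower number from compound 1 to compound 2 (0.97 log units; beyond the scatter), which is modest but beyond the scatter. It gives a span for the series, not a size for this change, so no direction can be set from compound 3.

Compound 4 is therefore expected to fall near the span set by compound 2 at 2.24 nM and compound 1 at 20.9 nM. The step is estimated as a step that the limit leaves unreadable from compound 3 to compound 4, resting on that span alone. For compound 4 the estimated value is 7 nM, with an expected range of 1.5 nM to 35 nM.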

Compound 4, half-maximal effective concentration: 130 nM
The estimate for compound 4 lay 19-fold (1.27 log units) below the measured number; measured number above the stated range.
By their numbers in this assay, from the lowest: compound 2; then compound 1; then compound 4.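

In this assay the readable steps to the new side chain, 4-phenylbut-1-yn-1-yl, are a 58-fold higher number from compound 2 to compound 4 (1.76 log units; beyond the scatter) and a 6.2-fold higher number from compound 1 to compound 4 (0.79 log units; beyond the scatter), so the numbers in the series now reach beyond both earlier values. Among the compounds shown here, the second step is the first readable change within a chain on the triple-bonded carbon, and it shows that an end phenyl brings no gain over the end hydroxyl of 6-hydroxyhex-1-yn-1-yl. Compound 3 stands only as a limit, > 0.1 nM, and the steps to and from it cannot be read: the limit of > 0.1 nM in this assay, at which 1 of the 4 values shown sits.

One readable step within such a chain does not separate the effect of adding phenyl from that of losing the hydroxyl. It also leaves open how a chain ending in an amine or a carboxylic acid would read at this place.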